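The source may report more compounds than this note shows. Statements on the series, on what has been measured and on what is new or still open speak of the compounds shown alone.

Compound 1 `N#CC1(NC(=O)[C@@H]2C[C@@H](S(=O)(=O)c3ccccc3)C[C@H]2C(=O)N2CCOCC2)CC1` and compound 2 `N#CC1(NC(=O)[C@@H]2C[C@@H](S(=O)(=O)c3ccccc3)C[C@H]2C(=O)N2CCNCC2)CC1` share one core and differ only in the ring on the carbonyl carbon. In an assay on isolated protein for inhibition of cathepsin S (Homo sapiens), read by fluorescence, with a stated time of 20 min (a lower number here means a stronger inhibitor, a higher number a weaker inhibitor), compound 1 gives 0.7 nM, and compound 2 gives 11 nM, the higher of the two numbers, with a 16-fold higher number from compound 1 to compound 2 (1.20 log units; beyond the scatter) between them. Compound 3 `N#CC1(NC(=O)[C@@H]2C[C@@H](S(=O)(=O)c3ccccc3)C[C@H]2C(=O)N2CCC(O)CC2)CC1` has not been measured yet; its change from compound 2 is 4-hydroxypiperidin-1-yl in place of piperazin-1-yl on a carbonyl carbon. Among the compounds with values here, the only step that bears on it is the one from compound 1 to compound 2, so the expectation for compound 3 is a step of a 4.4-fold lower number from compound 2 to compound 3 (0.64 log units; beyond the scatter), giving an estimated 2.5 nM within 0.8 nM to 8 nM in this assay.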

Compound 3, half-maximal inhibitory concentration: 1 nM
Beside the measured number, compound 3's estimate is 2.5-fold (0.40 log units) above it; the measured number falls inside the stated range.
By their numbers in this assay, from the lowest: compounds 1 and 3 (each within the scatter of the next); then compound 2.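

Piperazin-1-yl now stands apart from two other rings rather than from morpholin-4-yl alone, since 4-hydroxypiperidin-1-yl also brings a large improvement (an 11-fold lower number from compound 2 to compound 3 (1.04 log units; beyond the scatter)). Set against morpholin-4-yl, the new ring shows no real difference (a 1.4-fold higher number from compound 1 to compound 3 (0.15 log units; within the scatter)), so two different rings on this carbonyl carbon give matching numbers. Nothing available here explains these numbers.

Still open, as far as these compounds go, is how piperidin-1-yl, the same ring without the hydroxyl, would compare with compound 3. Also open, from the compounds shown here alone, is whether a carboxylic acid in place of that hydroxyl would keep the number.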